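Swapping sec-butyl for cyclohexyl in a macrocyclic series

A few compounds are considered here, and "the series" means these few. Any claim that something is new, unique, unknown or untested is made for them only; others in the source may bear on it.

Compound 1 `C[C@@H]1C(=O)N[C@H](Cc2ccc(F)cc2)C(=O)NCCCc2ccccc2OCCN[C@@H](C2CC2)C(=O)N1C`: 72 mL/min/kg
Compound 2 `CC[C@H](C)[C@@H]1NC[C@@H](C)Oc2ccccc2CCCNC(=O)[C@@H](Cc2ccc(F)cc2)NC(=O)[C@@H](C)N(C)C1=O`: 40 mL/min/kg
Compound 3 `C[C@@H]1CN[C@@H](C2CC2)C(=O)N(C)[C@H](C)C(=O)N[C@H](Cc2ccccc2)C(=O)NCCCc2ccccc2O1`: 25 mL/min/kg

These three compounds share a macrocyclic core and have each been run in an in vivo ADME assay on the whole organism (strain Sprague-Dawley) for pharmacokinetics, with Rattus norvegicus as the target; on this read-out lower numbers stand for slow clearance and higher numbers for fast clearance. Compound 2 sits in the middle of the three numbers, but its gap to compound 3, the nearest, and its gap to compound 1, the furthest, both fall within the usual scatter of this assay, so the three cannot be told apart with any confidence.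

Compound 4 `C[C@@H]1CN[C@@H](C2CCCCC2)C(=O)N(C)[C@H](C)C(=O)N[C@H](Cc2ccc(F)cc2)C(=O)NCCCc2ccccc2O1` has not yet been measured. It differs from compound 2 in one place: cyclohexyl in place of sec-butyl on a saturated ring carbon. Going by the values given here, no pair of measured compounds shows this change on its own, so there is no measured step to lean on. What the data do show is that compound 1 at 72 mL/min/kg and compound 3 at 25 mL/min/kg bracket compound 2 closely, all within the scatter, while the groups on the ring carbon vary from cyclopropyl to sec-butyl.

For compound 4 the expected step of a 1.1-fold higher number from compound 2 to compound 4 (0.05 log units; within the scatter) in this assay is small, with no clear direction, and not beyond the scatter. The estimate for compound 4 is therefore 45 mL/min/kg, with a range from 20 mL/min/kg to 100 mL/min/kg.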

Compound 4, clearance: 43 mL/min/kg
For compound 4 the middle estimate is 1.0-fold (0.02 log units) above the measured one; the measured number falls inside the stated range.
By their numbers in this assay, from the lowest: compounds 3, 2, 4 and 1 (each within the scatter of the next, the first and the last beyond it).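

Read in this assay, cyclohexyl in place of sec-butyl on this saturated ring carbon gives a 1.1-fold higher number from compound 2 to compound 4 (0.03 log units; within the scatter), the first step measured at this position, so compound 2 and compound 4 cannot be told apart on clearance. For this pair, then, the position takes a six-membered non-aromatic ring of carbon only in place of an open branched group, and the read-out shows no change beyond the usual variation between repeats, even though the group that leaves carries a defined stereocentre and the one that enters does not. The data shown hold no measurement that gives a reason for this result.

Going by these compounds alone, this is a single pair, and the cyclopropyl of compound 1 and compound 3 comes with other differences from compound 2, so it gives no clean step at this position. On these data alone, whether a phenyl ring, a longer chain such as n-hexyl, or a cyclohexyl bearing an amine or a carboxylic acid would leave the clearance equally unmoved stays open, as does whether the same swap would behave alike on the core of compound 3.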